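Pyridin-4-yl in place of 2-methoxyphenyl: stability outlook

A few compounds are considered here, and "the series" means these few. Any claim that something is new, unique, unknown or untested is made for them only; others in the source may bear on it.

In an ADME assay on microsomes from liver (Homo sapiens), read by LC-MS, using NADPH, with a stated time of 10 min, tested at 0.5 uM (on this read-out higher numbers stand for a more stable compound and lower numbers for a less stable compound), compound 3 `COc1ccccc1-c1cccc(-c2cc3nc(C)c([C@H](OC(C)(C)C)C(=O)O)c(-c4cc(F)c5c(c4C)CCCO5)n3n2)c1` gives 99%. Compound 1 `Cc1ccc(-c2cc3nc(C)c(C(OC(C)(C)C)C(=O)O)c(-c4cc(F)c5c(c4C)CCCO5)n3n2)cc1` gives 95% and compound 2 `Cc1nc2cc(-c3cccc(-c4ccccc4)c3)nn2c(-c2cc(F)c3c(c2C)CCCO3)c1[C@H](OC(C)(C)C)C(=O)O` gives 78%. The gap between compound 3 and compound 1 lies within the usual scatter, while the gap between compound 3 and compound 2 lies beyond it. Compound 4 `Cc1nc2cc(-c3cccc(-c4ccncc4)c3)nn2c(-c2cc(F)c3c(c2C)CCCO3)c1[C@H](OC(C)(C)C)C(=O)O` remains unmeasured and differs from compound 3 as follows: pyridin-4-yl in place of 2-methoxyphenyl on an aromatic carbon. The change places pyridin-4-yl on an aromatic carbon, meta to a large group. Among the compounds with values here, the only measured step bearing on it is a number 21 percentage points higher from compound 2 to compound 3 (beyond the scatter), a modest step with methoxy in place of hydrogen on an aromatic carbon. Within the data shown here, compound 4 has no methoxy, but no measured compound carries pyridin-4-yl. The expected change is a number 11 percentage points lower from compound 3 to compound 4 (beyond the scatter), a smaller fall than that step would reverse in full. In this assay the estimated value for compound 4 is 88%, with an expected range of 72% to 99%.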

Compound 4, percent of the compound remaining: 46%
The estimate for compound 4 lay 42 percentage points above the measured number, and the stated range ends above it.
By their numbers in this assay, from the lowest: compound 4; then compound 2; then compounds 1 and 3 (each within the scatter of the next).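

In this assay pyridin-4-yl at this aromatic carbon gives a number 53 percentage points lower from compound 3 to compound 4 (beyond the scatter) against 2-methoxyphenyl and also a number 32 percentage points lower from compound 2 to compound 4 (beyond the scatter) against phenyl. The fall therefore goes beyond the loss of the methoxy, and this position is sensitive to a change from a carbon-only ring to a ring with a hetero atom. No measurement on hand accounts for the fall.

Still open, on these data alone, is whether pyridin-3-yl at the same carbon would fall as far. Also open, as far as these compounds go, is how a phenyl carrying an amine would compare with compound 2 and compound 4 here.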